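Benzyl para-substituent swap in the glycinamide series

The source may report more compounds than this note shows. Statements on the series, on what has been measured and on what is new or still open speak of the compounds shown alone.

Measured so far:
compound 1 `O=C(O)CNC(=O)c1c(O)c2c(n(Cc3ccc(C(F)(F)F)cc3)c1=O)CCOC2` — 14 nM
compound 2 `O=C(O)CNC(=O)c1c(O)c2c(n(Cc3ccc(C(F)(F)F)cc3)c1=O)COC2` — 3.6 nM

In an assay on Sf9 cells for inhibition of prolyl hydroxylase EGLN2 (Homo sapiens), read by TR-FRET, with stated times of 30 min and 2 h (a lower number here means a stronger inhibitor, a higher number a weaker inhibitor), compound 2 gives 3.6 nM, the lowest of the two numbers recorded. Compound 1, which shares the benzyl group but differs in the fused ring of the core, gives 14 nM in this assay, a higher number beyond the scatter.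

The next compound, compound 3 `CC(C)(O)c1ccc(Cn2c3c(c(O)c(C(=O)NCC(=O)O)c2=O)COC3)cc1`, keeps the core of compound 2 and changes only the benzyl substituent: 1-hydroxy-1-methylethyl in place of trifluoromethyl on an aromatic carbon. Among the compounds with values here, no pair of measured compounds shows this change, so there is nothing to size it; the only comparison available concerns the core, not the benzyl group.

Expectation: the step from compound 2 to compound 3 is estimated as a 2.2-fold higher number from compound 2 to compound 3 (0.35 log units; beyond the scatter), a small move toward a higher number, close to the edge of the scatter. Compound 3 is thus estimated at 8 nM in this assay, with a range from 2.5 nM to 25 nM.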

Compound 3, half-maximal inhibitory concentration: 6.2 nM
The estimate for compound 3 lay 1.3-fold (0.11 log units) above the measured number, within the range that was stated.
By their numbers in this assay, from the lowest: compounds 2 and 3 (each within the scatter of the next); then compound 1.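

In this assay, within the data shown here, 1-hydroxy-1-methylethyl in place of trifluoromethyl on the benzyl group gives a 1.7-fold higher number from compound 2 to compound 3 (0.24 log units; within the scatter), so on this core the position takes the exchange with no step that stands clear of the scatter. The entering group carries 1 hydrogen-bond donor and 1 hydrogen-bond acceptor where trifluoromethyl carries 0 of each, at the same count of 4 heavy atoms, and this difference leaves the number within the scatter. Nothing at hand bears on why the two groups read alike.

As far as these compounds go, whether an amine, a carboxylic acid or a longer chain at this position would also stay within the scatter remains open. Also open, from the compounds shown here alone, is whether 1-hydroxy-1-methylethyl gives a similar step on the core of compound 1.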